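A few compounds are considered here, and "the series" means these few. Any claim that something is new, unique, unknown or untested is made for them only; others in the source may bear on it.

Measured compounds in a functional assay on MCF7 cells (Homo sapiens) for cytotoxicity, read by sulforhodamine B assay, with a stated time of 48 h; a lower number here means a stronger inhibitor of growth, a higher number a weaker inhibitor of growth:
- compound 1 `NC(=S)N/N=C1/C(=O)N(CN2CCN(c3ccnc4cc(Cl)ccc34)CC2)c2cc(Cl)ccc21`: 22500 nM
- compound 2 `NC(=S)N/N=C1/C(=O)N(CN2CCN(c3ccnc4cc(Cl)ccc34)CC2)c2cc(Br)ccc21`: 11400 nM
- compound 3 `NC(=S)N/N=C1/C(=O)N(CN2CCN(c3ccnc4cc(Cl)ccc34)CC2)c2ccccc21`: 23000 nM

Compound 1 stands second highest of the three numbers; its nearest neighbour is compound 3, its furthest is compound 2. The three steps that link them all move within the scatter: a 2.0-fold lower number from compound 1 to compound 2 (0.30 log units; within the scatter); a 1.0-fold higher number from compound 1 to compound 3 (0.01 log units; within the scatter); a 2.0-fold higher number from compound 2 to compound 3 (0.30 log units; within the scatter). None of them alters the part of the shared core that is touched now.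

Compound 4 `NC(=S)N/N=C1/C(=O)N(CN2CCN(c3ccnc4cc(C(F)(F)F)ccc34)CC2)c2cc(Cl)ccc21` differs from compound 1 in one place: trifluoromethyl in place of chloro on an aromatic carbon. The substituent exchanged here sits on an aromatic carbon of a six-membered aromatic ring of carbon only, part of a fused or bridged system of two rings, meta to a fused ring and para to a fused ring. Going by the values given here, no measured step varies this substituent; the measured steps vary the other halogen of the core and stay within the scatter. Nothing in the series therefore points to a step beyond the scatter in this assay, in either direction, and the estimate for compound 4 is 20000 nM (range 7000 nM to 60000 nM), which is expected to mean a 1.1-fold lower number from compound 1 to compound 4 (0.05 log units; within the scatter).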

Compound 4, concentration for 50% growth inhibition: 24600 nM
Compound 4: middle estimate off by 1.2-fold (0.09 log units), on the low side; the range from low to high includes it.
By their numbers in this assay, from the lowest: compounds 2, 1, 3 and 4 (each within the scatter of the next, the first and the last beyond it).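

Earlier steps vary only the other halogen of the core, whereas this one changes the substituent on the aromatic carbon meta to a fused ring and para to a fused ring of the two-ring system. In this assay, replacing chloro with trifluoromethyl at this position gives a 1.1-fold higher number from compound 1 to compound 4 (0.04 log units; within the scatter), so this single exchange, from 1 heavy atom to 4 heavy atoms, does not move the number beyond the scatter. No available evidence bears on this result.

Going by these compounds, whether an amine, a carboxylic acid or hydrogen at this position would give a step beyond the scatter remains open. On these data alone, it is also open whether the trifluoromethyl exchange would read the same with bromo or hydrogen in place of the chloro on the other ring of the shared core.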